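Acylthiourea pyrazole series: removing the aryl fluorine

The compounds below may be only part of what the source reports. "The series", "measured", "known", "first", "only" and "open" are said of these compounds alone.

Measured in a functional assay on MCF7 cells (Homo sapiens) for inhibition, read by CCK-8 assay, with a stated time of 48 h; on this read-out lower numbers stand for stronger inhibition and higher numbers for weaker inhibition:
compound 1 `O=C(NC(=S)Nc1ccc(Cl)cc1)c1cn(-c2ccccc2)nc1-c1ccc(Cl)cc1` gives 5360 nM
compound 2 `Cc1ccc(NC(=S)NC(=O)c2cn(-c3ccccc3)nc2-c2ccccc2)cc1` gives 5900 nM
compound 3 `O=C(NC(=S)Nc1ccc(Cl)cc1)c1cn(-c2ccccc2)nc1-c1ccc(F)cc1` gives 5470 nM

Compound 3 stands second highest of the three numbers; its nearest neighbour is compound 1, its furthest compound 2, and both gaps lie within the scatter. Among the measured compounds shown here, the three numbers so far are, in effect, indistinguishable.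

Compound 4 `O=C(NC(=S)Nc1ccc(Cl)cc1)c1cn(-c2ccccc2)nc1-c1ccccc1` has not yet been measured in this assay. It differs from compound 3 by hydrogen in place of fluoro on an aromatic carbon, that is, 4-fluorophenyl becomes phenyl at the pyrazole ring of the shared core.

For the measured compounds named here, the one measured step that touches this position is a 1.0-fold higher number from compound 1 to compound 3 (0.01 log units; within the scatter), which did not move the number beyond the scatter. Compound 2, which already carries the plain phenyl at that position but a methyl instead of chloro on the thiourea aryl, gives 5900 nM, again close to compound 1 and compound 3. Nothing in the measured pairs points to a change in this assay when the para substituent is removed.

For compound 4 the expected step is therefore a 1.0-fold higher number from compound 3 to compound 4 (0.01 log units; within the scatter), with no movement beyond the scatter anticipated. The estimate for compound 4 in this assay is 5600 nM, with a range from 2800 nM to 11200 nM.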

Compound 4, half-maximal inhibitory concentration: 6230 nM
Compound 4: the middle estimate sits 1.1-fold (0.05 log units) below what was measured; low and high end bracket the measured number.
By their numbers in this assay, from the lowest: compounds 1, 3, 2 and 4 (each within the scatter of the next).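

In this assay, the change from 4-fluorophenyl to phenyl gives a 1.1-fold higher number from compound 3 to compound 4 (0.06 log units; within the scatter) and the route from the chloro analogue gives a 1.2-fold higher number from compound 1 to compound 4 (0.07 log units; within the scatter), so hydrogen now joins fluoro and chloro at this position with no separation on this read-out. Among the compounds shown here, with the plain phenyl held fixed, the substituent on the thiourea aryl can also be read for the first time, and chloro in place of methyl gives a 1.1-fold higher number from compound 2 to compound 4 (0.02 log units; within the scatter), so this second position likewise shows no separation between the two groups tried. All four compounds therefore form one flat set in which neither single change moves the number beyond the scatter, and no measurement on hand speaks to the reason for this flatness.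

How an amine or a carboxylic acid in place of the fluoro on this phenyl would read remains open, since the groups shown here are only hydrogen and two halogens. Also open, from the compounds shown here alone, is whether a methoxy group or a longer alkyl chain on the thiourea aryl would separate from the chloro and methyl pair.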